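From compound 3 to compound 4: one ring for another

The source may hold more compounds than are shown below. What is called first, only, known or untested is meant among the compounds shown, and "the series" means these compounds.

Of the compounds shown here, three built on the same core have been tested in a functional assay on DU-145 cells (Homo sapiens) for cytotoxicity, read by MTT assay, with a stated time of 48 h; on this read-out lower numbers stand for stronger inhibition and higher numbers for weaker inhibition. Compound 1 `O=C(NCc1ccccc1)N(Cc1ccccn1)n1cnnc1` gives 21200 nM, and compound 2 `Cc1ccc(NC(=O)N(Cc2ccccn2)n2cnnc2)cc1` gives 21500 nM; the step of a 1.0-fold higher number from compound 1 to compound 2 (0.01 log units; within the scatter) leaves the number essentially unchanged. Compound 3 `Cc1ccsc1CN(C(=O)Nc1ccccc1)n1cnnc1` reaches only a limit of the assay, > 50000 nM. Compound 3 therefore stands apart at the weak end because it sits at the limit of > 50000 nM in this assay, at which 1 of the 3 values shown sits. Compound 4 `O=C(Nc1ccccc1)N(Cc1ccccn1)n1cnnc1` differs from compound 3 by pyridin-2-yl in place of 3-methylthiophen-2-yl on a saturated chain carbon bound to an amide-type nitrogen. Among the compounds with values here, no measured step tests this exchange directly, yet compound 1 and compound 2, both carrying the pyridin-2-yl group, give measurable numbers where compound 3 does not. A step of an at least 2.0-fold lower number from compound 3 to compound 4 (0.30 log units; that floor lies within the scatter) towards stronger inhibition is therefore expected. Compound 4 is estimated at 25000 nM, with a likely range from 10000 nM to 60000 nM.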

Compound 4, half-maximal inhibitory concentration: 20200 nM
Compound 4: the middle estimate sits 1.2-fold (0.09 log units) above what was measured; low and high end bracket the measured number.
By their numbers in this assay, from the lowest: compounds 4, 1 and 2 (each within the scatter of the next). At a limit, above all of these: compound 3.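

In this assay, pyridin-2-yl in place of 3-methylthiophen-2-yl gives an at least 2.4-fold lower number from compound 3 to compound 4 (0.39 log units; beyond the scatter), the only change shown here that moves the number beyond the scatter. Compound 3 gives only a limit, so the full size of that step stays unknown: the limit of > 50000 nM in this assay, at which 1 of the 4 values shown sits.

The changes elsewhere do much less, with phenyl in place of benzyl giving a 1.0-fold lower number from compound 1 to compound 4 (0.02 log units; within the scatter) and hydrogen in place of methyl giving a 1.1-fold lower number from compound 2 to compound 4 (0.03 log units; within the scatter).

Whether the ring itself or its methyl group accounts for the step stays open, and plain thiophen-2-yl would separate the two. From the compounds shown here alone, what an amine or a carboxylic acid on the phenyl group would do also stays open.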